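The source may hold more compounds than are shown below. What is called first, only, known or untested is meant among the compounds shown, and "the series" means these compounds.

Working notes on the series, step compound 3 to compound 4.

Compound 3 `CN1CCN(c2ccc(Nc3nc(-c4cccc(NC(=O)c5cccc(F)c5)c4)sc3C(=O)O)cc2)CC1` is the acid of the pair; in a functional assay on Raji cells (Homo sapiens) for antiproliferative activity, read by CCK-8 assay, with a stated time of 72 h, tested at 40 uM (on this read-out higher numbers stand for more inhibition at the one concentration tested (going by the name of the read-out) and lower numbers for less inhibition), compound 3 gives 76.3%. Among the three measured compounds it stands second highest. Its closest neighbour is compound 1 `CCOC(=O)c1sc(-c2cccc(NC(=O)c3cccc(F)c3)c2)nc1Nc1ccc(N2CCN(C)CC2)cc1`, which in this assay gives 82.8%; the step of a number 6.5 percentage points lower from compound 1 to compound 3 (within the scatter) is within the scatter, so the two are not separated. Compound 2 `CCOC(=O)c1sc(-c2cccc(NC(=O)c3ccc(Cl)cc3)c2)nc1Nc1ccc(N2CCN(C)CC2)cc1` gives 24.3% in this assay and lies well apart from compound 3.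

Compound 4 `CN1CCN(c2ccc(Nc3nc(-c4cccc(NC(=O)c5ccc(F)c(Cl)c5)c4)sc3C(=O)O)cc2)CC1` differs from compound 3 in a single place: 3-chloro-4-fluorophenyl in place of 3-fluorophenyl on a carbonyl carbon.

Within the data shown here, only one measured step touches the same carbonyl carbon: a number 58.5 percentage points lower from compound 1 to compound 2 (beyond the scatter), a large fall when 4-chlorophenyl replaces 3-fluorophenyl. Among the measured compounds shown here, no measured step introduces chlorine while the fluorine is kept, and the acid pair gives no reading on this position. For the measured compounds named here, the one relevant step therefore points downward, and the move to compound 4 is expected to lose inhibition in this assay, with the size uncertain because the change is not the same as in a number 58.5 percentage points lower from compound 1 to compound 2 (beyond the scatter). The estimate for compound 4 is 45%, range 15% to 75%, which means an expected step of a number 31.3 percentage points lower from compound 3 to compound 4 (beyond the scatter).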

Compound 4, a percentage reported as inhibition, at one concentration (the size of the read-out at that concentration, not a potency): 87.9%
For compound 4 the middle estimate is 42.9 percentage points below the measured one; measured number above the stated range.
By their numbers in this assay, from the lowest: compound 2; then compounds 3, 1 and 4 (each within the scatter of the next, the first and the last beyond it).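

On the carbonyl carbon, a chlorine-bearing aryl group is not tied to a loss: in this assay the change to 3-chloro-4-fluorophenyl gives a number 11.6 percentage points higher from compound 3 to compound 4 (beyond the scatter) and thus runs opposite to a number 58.5 percentage points lower from compound 1 to compound 2 (beyond the scatter) in the earlier pair. The two steps differ in the entering group, 3-chloro-4-fluorophenyl against 4-chlorophenyl, and in the compound they start from, an acid against an ethyl ester, so this position responds to the exact group and its setting rather than to the presence of chlorine alone. No measurement shown here explains the rise or the opposite direction of the two steps.

The compounds shown leave open whether the fall seen with 4-chlorophenyl also occurs in the acid, and whether the ethyl ester carrying 3-chloro-4-fluorophenyl keeps the level seen in the acid. They also leave open how 3-chlorophenyl or 4-fluorophenyl alone would read on this carbonyl carbon, which would show whether the rise needs both halogens, and the single tested concentration gives no potency for any of these compounds.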